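Chain extension of the isothiocyanate linker in compound 2

The compounds below may be only part of what the source reports. "The series", "measured", "known", "first", "only" and "open" are said of these compounds alone.

Measured so far:
compound 1, `CN(C)C(=O)c1cc2cnc(Nc3ccc(S(=O)(=O)NCCCCN=C=S)cc3)nc2n1C1CCCC1`: 39.4%
compound 2, `CN(C)C(=O)c1cc2cnc(Nc3ccc(NC(=O)CCCN=C=S)cc3)nc2n1C1CCCC1`: 56.1%

Both numbers come from a functional assay on A549 cells (Homo sapiens) for inhibition, read by CCK-8 assay, with a stated time of 72 h, tested at 1 uM; on this read-out lower numbers stand for a weaker effect and higher numbers for a stronger effect at the one concentration tested. Compound 2 holds the higher of the two numbers. For the measured compounds named here, the single measured step, a number 16.7 percentage points higher from compound 1 to compound 2 (beyond the scatter), exchanges the linker on the aromatic carbon and lies beyond the scatter; it says nothing about the length of the chain that carries the isothiocyanate.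

Compound 3, `CN(C)C(=O)c1cc2cnc(Nc3ccc(NC(=O)CCCCCCN=C=S)cc3)nc2n1C1CCCC1`, differs from compound 2 by a group of 6 heavy atoms (4 carbon, 1 nitrogen, 1 sulfur; no ring) in place of a group of 3 heavy atoms (1 carbon, 1 nitrogen, 1 sulfur; no ring), on a saturated chain carbon, three bonds along the chain from a carbonyl carbon. Going by the values given here, no measured step bears on this kind of change, so there is no basis to expect a move in either direction; the default expectation is a step within the scatter, with widened uncertainty for the longer chain. In this assay compound 3 is therefore expected to give about 55%, with a range of 35% to 75%. The expected step, a number 1.1 percentage points lower from compound 2 to compound 3 (within the scatter), is estimated to stay within the scatter.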

Compound 3, a percentage reported as inhibition, at one concentration (the size of the read-out at that concentration, not a potency): 43.3%
Beside the measured number, compound 3's estimate is 11.7 percentage points above it, within the range that was stated.
By their numbers in this assay, from the lowest: compounds 1 and 3 (each within the scatter of the next); then compound 2.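

In this assay, chain length on the carbonyl-bearing linker matters: the group of 6 heavy atoms in place of the group of 3 heavy atoms, on a saturated chain carbon, three bonds along the chain from a carbonyl carbon, gives a number 12.8 percentage points lower from compound 2 to compound 3 (beyond the scatter). The edge that the shorter chain held over the sulfonamide-linked compound does not persist with the longer chain, which shows a number 3.9 percentage points higher from compound 1 to compound 3 (within the scatter). Nothing available bears on the reason for the step with chain length.

From the compounds shown here alone, two chain lengths on this linker do not define a trend, so it remains open how chains of intermediate length, or a longer chain still, would behave. Going by these compounds, it also remains open whether the isothiocyanate is needed, which an amine or a carboxylic acid at the chain end would test.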